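The compounds below may be only part of what the source reports. "The series", "measured", "known", "first", "only" and "open" are said of these compounds alone.

Compound 1 `COc1cccc(C(=O)Oc2ccc3c(=O)c(-c4cc(OC)c(OC)cc4OC)coc3c2)c1`: > 10000 nM
Compound 2 `COc1cc(OC)c(-c2coc3cc(OCc4ccc(Br)cc4)ccc3c2=O)cc1OC`: 1180 nM
Compound 3 `COc1cc(OC)c(-c2coc3cc(OCc4cccc(Br)c4)ccc3c2=O)cc1OC`: 4400 nM

These results come from a functional assay on B16 cells (Mus musculus) for antiproliferative activity, read by MTT assay, with a stated time of 24 h; a higher number here means a weaker inhibitor, a lower number a stronger inhibitor. The entry for compound 1 is a limit of the assay, not a number. Of the two actual numbers, the higher belongs to compound 3, at 4400 nM.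

Compound 4 `COc1cc(OC)c(-c2coc3cc(OCc4ccc(C(F)(F)F)cc4)ccc3c2=O)cc1OC` differs from it as follows: 4-(trifluoromethyl)phenyl in place of 3-bromophenyl on a saturated chain carbon bound to an oxygen on an aromatic ring. Here, 4-(trifluoromethyl)phenyl replaces 3-bromophenyl on a saturated chain carbon bound to an oxygen on an aromatic ring.

The closest guide is a 3.7-fold higher number from compound 2 to compound 3 (0.57 log units; beyond the scatter), where 3-bromophenyl replaced 4-bromophenyl. The steps of an at least 8.4-fold lower number from compound 1 to compound 2 (0.92 log units; beyond the scatter) and an at least 2.2-fold lower number from compound 1 to compound 3 (0.35 log units; beyond the scatter) exchange a different group, so they say less. Going by the values given here, no measured compound carries trifluoromethyl, so only a modest drop is expected, namely a 2.2-fold lower number from compound 3 to compound 4 (0.34 log units; beyond the scatter).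

The estimate for compound 4 is 2000 nM, with an expected range of 700 nM to 6000 nM.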

Compound 4, half-maximal inhibitory concentration: 5400 nM
Beside the measured number, compound 4's estimate is 2.7-fold (0.43 log units) below it; the range from low to high includes it.
By their numbers in this assay, from the lowest: compound 2; then compounds 3 and 4 (each within the scatter of the next). At a limit, above all of these: compound 1.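

Putting 4-(trifluoromethyl)phenyl in place of 3-bromophenyl on a saturated chain carbon bound to an oxygen on an aromatic ring gives a 1.2-fold higher number from compound 3 to compound 4 (0.09 log units; within the scatter), so compound 3 and compound 4 lie within the scatter of each other. With trifluoromethyl in place of bromo on an aromatic carbon, there is instead a 4.6-fold higher number from compound 2 to compound 4 (0.66 log units; beyond the scatter), and compound 2 therefore stands apart from both compound 3 and compound 4. The entry for compound 1 is a limit of the assay, not a number. The step of an at least 1.8-fold lower number from compound 1 to compound 4 (0.26 log units; that floor lies within the scatter) therefore cannot be read: the limit of > 10000 nM in this assay, at which 1 of the 4 values shown sits.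

As far as these compounds go, whether an amine or a carboxylic acid on this aromatic ring, or a longer chain in place of the saturated chain carbon, could match compound 2 remains open.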